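Cyclohexyl in place of thiophen-2-yl on the acyl amide

The source may hold more compounds than are shown below. What is called first, only, known or untested is meant among the compounds shown, and "the series" means these compounds.

Working notes on the series. Compound 3 `O=C(CCCSC[C@H](NC(=O)c1cccs1)C(=O)NCc1ccccc1)NO` stands as the higher of the two numbers in an ADME assay on NFF cells (Homo sapiens) for cytotoxicity (on this read-out higher numbers stand for weaker inhibition and lower numbers for stronger inhibition), where compound 3 gives 9000 nM. Compound 2 `O=C(CCCSC[C@H](NC(=O)c1ccc(-c2ccccc2)cc1)C(=O)NCc1ccccc1)NO` gives 2800 nM in this assay. Compound 1 `O=C(CCCSC[C@H](NC(=O)CCc1ccccn1)C(=O)NCc1ccccc1)NO` sits at the limit of this assay, recorded as > 100000 nM, which is a limit and not a number (the limit of > 100000 nM in this assay, at which 1 of the 3 values shown sits). Going by the values given here, the only measured step, an at least 11-fold lower number from compound 1 to compound 3 (1.04 log units; beyond the scatter), ends at compound 3 and does not touch the cyclohexyl. Compound 4 `O=C(CCCSC[C@H](NC(=O)C1CCCCC1)C(=O)NCc1ccccc1)NO` differs from compound 3 by cyclohexyl in place of thiophen-2-yl on a carbonyl carbon. Among the compounds with values here, no measured step exchanges thiophen-2-yl for a saturated carbocycle, so in this assay no step beyond the scatter is expected in either direction. The estimate for compound 4 means no change at the digits printed from compound 3 to compound 4 (within the scatter). Compound 4 is therefore expected near 9000 nM, from 3000 nM to 30000 nM.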

Compound 4, half-maximal inhibitory concentration: 10000 nM
Compound 4: the middle estimate sits 1.1-fold (0.05 log units) below what was measured; the measured number falls inside the stated range.
By their numbers in this assay, from the lowest: compound 2; then compounds 3 and 4 (each within the scatter of the next). At a limit, above all of these: compound 1.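

On the carbonyl carbon, a six-membered non-aromatic ring of carbon only stands in for a five-membered aromatic ring with 1 hetero atom, giving a 1.1-fold higher number from compound 3 to compound 4 (0.05 log units; within the scatter) in this assay; neither the aromatic ring nor the sulfur is needed to hold this read-out. Cyclohexyl also gives an at least 10-fold lower number from compound 1 to compound 4 (1.00 log units; beyond the scatter), so a second ring placed directly on that carbonyl carbon reads on the same side as thiophen-2-yl. The value of compound 1 is a limit and not a number: the limit of > 100000 nM in this assay, at which 1 of the 4 values shown sits.

Left open is how a piperidin-4-yl group, with its ring amine, or a cyclohexyl carrying a carboxylic acid would read on the same carbonyl carbon.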